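A few compounds are considered here, and "the series" means these few. Any claim that something is new, unique, unknown or untested is made for them only; others in the source may bear on it.

Measured so far:
compound 1, `COc1ccc(C2N=C(SCc3ccccc3)NC(C)=C2C(=O)Nc2ccc(F)cc2)cc1OC`: 3.6%
compound 2, `CC1=C(C(=O)Nc2ccc(Br)cc2)C(c2ccc(Cl)cc2Cl)N=C(SCc2ccccc2)N1`: 3.6%
compound 3, `CC1=C(C(=O)Nc2ccc([N+](=O)[O-])cc2)C(c2ccc(Br)cc2)N=C(SCc2ccccc2)N1`: 3.6%

All three readings come from a functional assay on the whole organism (artery, strain albino) with Rattus norvegicus as the target, with a stated time of 30 min, at a dose of 10 mg/kg by the oral route; a lower number here means less inhibition, a higher number more inhibition at the dose given (going by the name of the read-out). Compound 3 stands level with compounds 1 and 2 at the digits reported: against compound 1, its nearest neighbour in the readings, there is no change at the digits reported, and the same holds against compound 2, the furthest; both gaps lie within the scatter. Within the data shown here, the three compounds differ from one another in more than one place, so no single-change step between measured compounds is available, and the readings themselves are flat across the set.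

Compound 4, `CC1=C(C(=O)Nc2ccc([N+](=O)[O-])cc2)C(c2ccc(Br)cc2)N=C(SCc2ccc(F)cc2)N1`, has not yet been measured. It differs from compound 3 in one place: fluoro in place of hydrogen on an aromatic carbon. Going by these compounds, nothing in the measured set isolates this change, so its effect in this assay is unknown from the data. The step is expected to be none beyond the scatter, because compound 3 gives 3.6% and the whole measured set sits at the same low reading in this assay .

Compound 4 is therefore expected to read 3.6%, with a range of 0% to 15%.

This expectation corresponds to an estimated step of no change at the digits printed from compound 3 to compound 4 (within the scatter).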

Compound 4, a percentage reported as inhibition, in the whole organism at one dose (the size of the read-out at that dose, not a potency): 5.2%
Estimate against measurement, compound 4: 1.6 percentage points below, within the range that was stated.
By their numbers in this assay, from the lowest: compounds 1, 2, 3 and 4 (each within the scatter of the next).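

In this assay, going from benzylsulfanyl to (4-fluorobenzyl)sulfanyl gives a number 1.6 percentage points higher from compound 3 to compound 4 (within the scatter). Among these compounds, this is the first single-change comparison, and it shows that placing fluoro on this aromatic carbon, para to a large group, does not take the reading outside the scatter when the rest of compound 3 is held fixed. No data at hand bear on the cause of this result.

Going by these compounds, it remains open whether an amine or a carboxylic acid on the same aromatic carbon, or a longer chain such as phenethyl in place of the benzyl group, would move the reading in this assay beyond the scatter. On these data alone, with a single one-place comparison available, it is also open whether the same change would have a similar effect on the different substitution patterns of compound 1 and compound 2, which share the benzylsulfanyl group but differ from compound 3 in more than one place.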